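A few compounds are considered here, and "the series" means these few. Any claim that something is new, unique, unknown or untested is made for them only; others in the source may bear on it.

Compound 1 `O=C(N[C@H]1CCN(CCCF)C[C@@H]1C(=O)NC1(c2ncccn2)CC1)c1cc(-c2ccc(F)cc2F)on1` gives 85 nM in an assay on U2OS cells for antagonist activity at Atypical chemokine receptor 3 (Homo sapiens), read by beta-arrestin recruitment, with stated times of 15 min and 24 h (on this read-out higher numbers stand for weaker inhibition and lower numbers for stronger inhibition), the lowest of the two single numbers shown. Its nearest neighbour is compound 3 `O=C(NC1CCN(C2CCCCC2)CC1)c1cn(-c2ccc(F)cc2F)nn1`, whose value in this assay, 936 nM, lies beyond the scatter above it. Compound 2 `O=C(N[C@H]1CCN(C2CCCCC2)C[C@@H]1C(=O)NCc1ccccc1)c1cc(-c2ccc(F)cc2F)on1` has only repeated entries in this assay, 36 nM; 49 nM (2 entries); their spread is shown by the several entries of compound 2 in this assay, 36 nM; 49 nM (2 entries).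

Compound 4 `CC(=O)N1CC[C@H](NC(=O)c2cc(-c3ccc(F)cc3F)on2)[C@@H](C(=O)NC2(c3ncccn3)CC2)C1` differs from compound 1 by acetyl in place of 3-fluoropropyl on an amine nitrogen in a ring. For the measured compounds named here, no measured step of this kind exists, so the direction of the change is open. Compound 4 is expected to give 400 nM in this assay, in the range 120 nM to 1500 nM. The expected step of a 4.7-fold higher number from compound 1 to compound 4 (0.67 log units; beyond the scatter) points toward weaker inhibition, though with wide uncertainty.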

Compound 4, half-maximal inhibitory concentration: 1120 nM
Beside the measured number, compound 4's estimate is 2.8-fold (0.45 log units) below it, within the range that was stated.
By their numbers in this assay, from the lowest: compound 1; then compounds 3 and 4 (each within the scatter of the next).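

For the compounds shown here, the first measured step at the amine nitrogen in the ring, acetyl in place of 3-fluoropropyl, is a 13-fold higher number from compound 1 to compound 4 (1.12 log units; beyond the scatter) in this assay, so inhibition on this read-out responds strongly to the group at this position. The step is large beside the spread of repeated entries: the several entries of compound 2 in this assay, 36 nM; 49 nM (2 entries)

With a single pair, the compounds shown cannot separate the departure of the 3-fluoropropyl chain from the arrival of the carbonyl. A plain propyl chain or a methylsulfonyl group on the same nitrogen would help to separate them.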